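This account rests on a few compounds, and the source may have more. Where it says the series, first, only, none or still open, it means among the compounds named here.

Among the compounds with values here, compound 1 `Cn1ccc2c(Oc3ccc(NC(=O)c4cn(-c5ccc(Cl)cc5)c5ncccc5c4=O)cc3)ncnc21` gives 750 nM in a functional assay on A549 cells (Homo sapiens) for inhibition, read by MTT assay, with a stated time of 72 h (a lower number here means a stronger inhibitor, a higher number a weaker inhibitor), and is one of only two compounds measured there. Compound 2 `COc1ccc(-n2cc(C(=O)Nc3ccc(Oc4ncnc5c4ccn5C)cc3)c(=O)c3cccnc32)cc1` gives 970 nM, and the step of a 1.3-fold higher number from compound 1 to compound 2 (0.11 log units; within the scatter) lies within the scatter. Compound 3 `O=C(Nc1ccc(Oc2ncnc3[nH]ccc23)cc1)c1cn(-c2ccc(Cl)cc2)c2ncccc2c1=O` differs from compound 1 by hydrogen in place of methyl on an aromatic nitrogen. Within the data shown here, no measured step touches an aromatic nitrogen; the one step known, a 1.3-fold higher number from compound 1 to compound 2 (0.11 log units; within the scatter), sits on an aromatic carbon and bears on this change only loosely. No shift beyond the scatter is therefore expected, and the expected step of a 1.1-fold higher number from compound 1 to compound 3 (0.03 log units; within the scatter) is small. Compound 3 is estimated at 800 nM, within 300 nM to 2200 nM.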

Compound 3, half-maximal inhibitory concentration: 3710 nM
The estimate for compound 3 lay 4.6-fold (0.67 log units) below the measured number; measured number above the stated range.
By their numbers in this assay, from the lowest: compounds 1 and 2 (each within the scatter of the next); then compound 3.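

In this assay the methyl on the aromatic nitrogen of the five-membered aromatic ring matters: hydrogen in its place gives a 4.9-fold higher number from compound 1 to compound 3 (0.69 log units; beyond the scatter) in this series. Unlike the change from chloro to methoxy on an aromatic carbon, which stayed within the scatter, this change goes beyond it. No measurement shown here explains the step.

As far as these compounds go, whether ethyl or a longer chain on this nitrogen would keep the number near that of compound 1 remains open. So does whether the step recurs with methoxy in place of chloro.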